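Chloro-to-nitro swap carried over to a second core

This account rests on a few compounds, and the source may have more. Where it says the series, first, only, none or still open, it means among the compounds named here.

Measured compounds:
compound 1, `O=C(/C=C/c1ccc2no[n+]([O-])c2c1)c1ccc(Cl)cc1`, 28000 nM
compound 2, `O=C(/C=C/c1ccc2no[n+]([O-])c2c1)c1ccc([N+](=O)[O-])cc1`, 32000 nM
compound 3, `O=C(/C=C/c1ccc2nonc2c1)c1ccc(Cl)cc1`, 251000 nM

Of the compounds shown here, three have been measured in an ADME assay on J774 cells (Mus musculus) for cytotoxicity, read by MTT assay, with a stated time of 48 h; on this read-out lower numbers stand for stronger inhibition and higher numbers for weaker inhibition. Compound 1 gives 28000 nM and compound 2 gives 32000 nM, so the pair sits within the usual scatter of each other. The change between them is nitro in place of chloro on an aromatic carbon, and its step was a 1.1-fold higher number from compound 1 to compound 2 (0.06 log units; within the scatter). Compound 3 gives the highest of the three numbers in this assay, 251000 nM, a gap beyond the scatter from both compound 1 and compound 2. The difference between the core of compound 1 and the core of compound 3 is not broken down here.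

The unmeasured compound 4, `O=C(/C=C/c1ccc2nonc2c1)c1ccc([N+](=O)[O-])cc1`, differs from compound 3 by nitro in place of chloro on an aromatic carbon. This is the same change as the one from compound 1 to compound 2, made here on the core of compound 3, and it occurs twice among the compounds shown. Because the earlier step was a 1.1-fold higher number from compound 1 to compound 2 (0.06 log units; within the scatter), the same change on the core of compound 3 is expected to move the number little. Compound 4 is therefore estimated at 280000 nM in this assay, with an expected range from 120000 nM to 600000 nM. That estimate means an expected step of a 1.1-fold higher number from compound 3 to compound 4 (0.05 log units; within the scatter). Among the measured compounds shown here, the expectation rests on only one earlier example of this change, so it is held loosely.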

Compound 4, half-maximal inhibitory concentration: 131000 nM
Compound 4: the middle estimate sits 2.1-fold (0.33 log units) above what was measured; measured number inside the range.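

Carried to the second core, nitro in place of chloro gives a 1.9-fold lower number from compound 3 to compound 4 (0.28 log units; within the scatter) in this assay and so leaves the number within the usual scatter there as well. Set beside the earlier step, the change reads alike on the two cores: the same change on two cores in this assay, a 1.1-fold higher number (0.06 log units; within the scatter) from compound 1 to compound 2 and a 1.9-fold lower number (0.28 log units; within the scatter) from compound 3 to compound 4, 2.2-fold (0.34 log units) apart, within the scatter of two such steps. Among the compounds shown here, the two pairs therefore give no sign that the core alters what this swap does, but they are only two pairs, so they do not show that it would stay within the scatter on any further core, they do not explain why the two steps look as they do, and at this size the opposite directions of the two steps carry no meaning.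

The compounds shown leave open how other groups on this aromatic carbon, para to a large group, would read on either core, for example an amine, a carboxylic acid or a methoxy group. Also open, on these data alone, is whether the distance between compound 1 at 28000 nM and compound 3 at 251000 nM would persist with such groups in place of chloro.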